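The compounds below may be only part of what the source reports. "The series", "measured", "known", "first", "only" and "open" are said of these compounds alone.

Measured so far:
compound 1, `COc1ccc(/C=C\C(=O)O)c(OCc2cn(-c3ccc(NC(C)=O)cc3)nn2)c1CC=C(C)C`: 23400 nM
compound 2, `COc1ccc(/C=C\C(=O)O)c(OCc2cn(-c3cccnc3Cl)nn2)c1CC=C(C)C`: 32600 nM

Both numbers come from a functional assay on A-431 cells (Homo sapiens) for cytotoxicity, read by MTT assay, with a stated time of 24 h; on this read-out higher numbers stand for weaker inhibition and lower numbers for stronger inhibition. Compound 2 carries the higher of the two numbers, yet the step of a 1.4-fold higher number from compound 1 to compound 2 (0.14 log units; within the scatter) lies within the scatter, so the two compounds cannot be told apart on this measure. Compound 3, `COc1ccc(/C=C\C(=O)O)c(OCc2cn(-c3cccc([N+](=O)[O-])c3)nn2)c1CC=C(C)C`, has not yet been tested. It differs from compound 2 in one place: 3-nitrophenyl in place of 2-chloropyridin-3-yl on an aromatic nitrogen. Among the measured compounds shown here, the only measured step that bears on this change is the one just described, which swapped one aryl group for another on the aromatic nitrogen without moving the number beyond the scatter. For the measured compounds named here, with only that step to go on, a change of similar size is expected, that is, none beyond the scatter. For compound 3 the expected step is a 1.1-fold lower number from compound 2 to compound 3 (0.04 log units; within the scatter) in this assay. Compound 3 is therefore estimated at 30000 nM in this assay, with a likely range from 12000 nM to 75000 nM.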

Compound 3, half-maximal inhibitory concentration: 18400 nM
The estimate for compound 3 lay 1.6-fold (0.21 log units) above the measured number; low and high end bracket the measured number.
By their numbers in this assay, from the lowest: compounds 3, 1 and 2 (each within the scatter of the next).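

In this assay, replacing the aryl group on the aromatic nitrogen again gives a 1.8-fold lower number from compound 2 to compound 3 (0.25 log units; within the scatter), while the comparison with the remaining compound gives a 1.3-fold lower number from compound 1 to compound 3 (0.10 log units; within the scatter). Neither step lies beyond the scatter, so 2-chloropyridin-3-yl, 4-acetamidophenyl and 3-nitrophenyl cannot be told apart here, and that now holds for three aryl groups rather than one pair, including one whose ring is carbon only. No measured evidence accounts for these numbers.

As far as these compounds go, all three groups are six-membered aromatic rings attached directly to the aromatic nitrogen, so it remains open whether a non-aromatic group there, such as a hexyl chain, or a benzyl group would shift the number beyond the scatter. From the compounds shown here alone, the effect of changing the shared core, including its carboxylic acid, also remains open.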